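The source may hold more compounds than are shown below. What is called first, only, known or untested is meant among the compounds shown, and "the series" means these compounds.

In a functional assay on PC-3 cells (Homo sapiens) (on this read-out lower numbers stand for stronger inhibition of growth and higher numbers for weaker inhibition of growth), compound 1 `O=S(=O)(/C=C/c1ccc(F)cc1F)Cc1ccc(Nc2ncnc3ccccc23)cc1` gives > 100000 nM, which is a limit and not a number. Compound 2 `O=S(=O)(/C=C/c1ccc(C(F)(F)F)cc1F)Cc1ccc(Nc2ncnc3ccccc23)cc1` gives 100000 nM. Compound 3 `O=S(=O)(/C=C/c1ccc(C(F)(F)F)cc1F)Cc1ccc(Nc2ncnc3cc(Cl)ccc23)cc1` gives > 100000 nM, which is also only a limit. This places compound 3 at the limit of > 100000 nM in this assay, at which 2 of the 3 values shown sit.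

Compound 4 `O=S(=O)(/C=C/c1ccc(F)cc1F)Cc1ccc(Nc2ncnc3cc(Cl)ccc23)cc1` differs from compound 3 by one change, fluoro in place of trifluoromethyl on an aromatic carbon. The same swap, run the other way, appears in a number no higher from compound 1 to compound 2 (the limit leaves the size open), while the chloro that compound 4 keeps was added in a number no lower from compound 2 to compound 3 (the limit leaves the size open). The limits leave the size of both steps open, so neither shows a real effect in this assay. The expected change is a number no higher from compound 3 to compound 4 (the limit leaves the size open), which means none beyond the scatter. For compound 4, the estimated value is 100000 nM, within an expected range of 50000 nM to 200000 nM.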

Compound 4, concentration for 50% growth inhibition: > 100000 nM
Compound 4 gave a limit, no number; the forecaster's own chance of this, stated with the estimate: 85%; the middle value sits exactly at the limit.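

Compound 4 gives > 100000 nM, which is only a limit. Its steps from compound 3 and compound 1, both also limits, cannot be read. The compounds shown leave open whether fluoro, trifluoromethyl or chloro changes anything in this assay.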